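The compounds below may be only part of what the source reports. "The series", "measured", "known", "first", "only" and "open" are said of these compounds alone.

In a functional assay on HepG2 cells (Homo sapiens) for antiproliferative activity, read by sulforhodamine B assay, with a stated time of 48 h (on this read-out higher numbers stand for weaker inhibition and lower numbers for stronger inhibition), compound 1 `COc1ccc(/C=C/C(=O)c2ccccc2-c2ccc(OC)c(OC)c2)cc1` gives 600 nM, compound 2 `COc1ccc(/C=C/C(=O)c2ccccc2-c2ccc(OC)c(OC)c2)cc1OC` gives 3200 nM and compound 3 `COc1ccc(OC)c(/C=C/C(=O)c2ccccc2-c2ccc(OC)c(OC)c2)c1` gives 2100 nM. Compound 3 stands apart from compound 1 only: the data show a 3.5-fold higher number from compound 1 to compound 3 (0.54 log units; beyond the scatter), but a 1.5-fold lower number from compound 2 to compound 3 (0.18 log units; within the scatter). Compound 4 `COc1ccc(OC)c(/C=C/C(=O)c2ccccc2-c2ccc(F)cc2)c1` carries 4-fluorophenyl in place of 3,4-dimethoxyphenyl on an aromatic carbon, ortho to a large group (4-fluorophenyl in place of 3,4-dimethoxyphenyl on an aromatic carbon). Going by the values given here, no measured step changes that group, since all three measured compounds share it. Among the compounds with values here, the only guide is the modest size of a 5.3-fold higher number from compound 1 to compound 2 (0.73 log units; beyond the scatter), a change made elsewhere, so the direction stays open and no step beyond the scatter is firmly expected. The expected change is a 1.2-fold higher number from compound 3 to compound 4 (0.08 log units; within the scatter). Compound 4 is estimated at 2500 nM, with an expected range of 800 nM to 7000 nM.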

Compound 4, half-maximal inhibitory concentration: 520 nM
Estimate against measurement, compound 4: 4.8-fold (0.68 log units) above; the measured number lies below the stated range.
By their numbers in this assay, from the lowest: compounds 4 and 1 (each within the scatter of the next); then compounds 3 and 2 (each within the scatter of the next).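

In this assay, putting 4-fluorophenyl in place of 3,4-dimethoxyphenyl on an aromatic carbon, ortho to a large group, gives a 4.0-fold lower number from compound 3 to compound 4 (0.61 log units; beyond the scatter). Going by these compounds alone, this is the first sign that this position, shared by the earlier compounds, bears on the read-out, and that the read-out can change here with the dimethoxy pattern on the other aryl group held fixed. Nothing measured here explains the step. On these data alone, it remains open whether the step follows from losing the two methoxy groups or from adding fluorine. As far as these compounds go, how phenyl, 4-chlorophenyl or 4-aminophenyl would read at this position also remains open.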